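Notes on the step to compound 3

The source may hold more compounds than are shown below. What is called first, only, known or untested is meant among the compounds shown, and "the series" means these compounds.

Measured in a functional assay on HT-29 cells (Homo sapiens) for inhibition, read by MTT assay, with a stated time of 72 h; a higher number here means a weaker inhibitor, a lower number a stronger inhibitor:
compound 1 `C=C(Br)C(=O)Nc1cccc(/C=C/C(=O)Nc2cccc3ccccc23)c1`: 6500 nM
compound 2 `C=C(Br)C(=O)Nc1cccc(/C=C/C(=O)Nc2cccc(F)c2)c1`: 4600 nM

Compound 2 stands at 4600 nM and compound 1 at 6500 nM, so the two values lie within the usual scatter of each other. Neither can be ranked on these numbers.

The next compound to be tested is compound 3 `C=C(Br)C(=O)Nc1cccc(/C=C/C(=O)NCc2ccc(C)cc2)c1`. It carries 4-methylbenzyl in place of 3-fluorophenyl on an amide-type nitrogen.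

Among the measured compounds shown here, no single-site step between measured compounds is available to size this change. Only the closeness of the two values offers a guide, so the expectation is a step no larger than the scatter, with no clear direction. The estimated change is a 1.1-fold higher number from compound 2 to compound 3 (0.04 log units; within the scatter). For compound 3 the expected value is 5000 nM, with an estimated range of 2000 nM to 13000 nM.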

Compound 3, half-maximal inhibitory concentration: 2700 nM
Compound 3: middle estimate off by 1.9-fold (0.27 log units), on the high side; the measured number falls inside the stated range.
By their numbers in this assay, from the lowest: compounds 3, 2 and 1 (each within the scatter of the next, the first and the last beyond it).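

In this assay, among the compounds shown here, the amide-type nitrogen takes 4-methylbenzyl in place of 3-fluorophenyl with a 1.7-fold lower number from compound 2 to compound 3 (0.23 log units; within the scatter), the first sized step at this position, and this step does not separate the two compounds. The two groups share one six-membered aromatic ring of carbon only and neither has hydrogen-bond donors or acceptors, so this step tests only a narrow kind of change on this nitrogen. Nothing available explains the size of this step.

Still open, as far as these compounds go, is how this nitrogen responds to a group with no aromatic ring, such as a longer alkyl chain, or to one bearing an amine or a carboxylic acid. The compounds shown also leave unresolved how the benzyl linkage and the ring substituents each contribute, since they change together in this step.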